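Carbamate Variation in a Low-Inhibition Series

The source may report more compounds than this note shows. Statements on the series, on what has been measured and on what is new or still open speak of the compounds shown alone.

Compound 2 `CC(C)=CCC1Cc2c(OCCCNC(=O)c3cccs3)cc(=O)n(CCCO)c2CC1(C)C` is one of two compounds tested in a functional assay on PANC-1 cells (Homo sapiens) for inhibition, read by MTT assay, with a stated time of 24 h, tested at 10 uM (a higher number here means more inhibition at the concentration tested (going by the name of the read-out), a lower number less inhibition), where compound 2 gives 5.6%. Compound 1 `CC(C)=CCOc1cc(=O)n(CCCO)c2c1CC(CC=C(C)C)C(C)(C)C2` gives 7.5%; the step of a number 1.9 percentage points lower from compound 1 to compound 2 (within the scatter) leaves the two within the usual scatter, so neither stands apart. Compound 3 `COc1ccc(NC(=O)Oc2cc(=O)n(CCCO)c3c2CC(CC=C(C)C)C(C)(C)C3)cc1` differs from compound 2 by (4-methoxyphenyl)carbamoyl in place of 3-(((thiophen-2-yl)carbonyl)amino)propyl on an oxygen on an aromatic ring. For the measured compounds named here, no measured step alters this oxygen-bound group, so the single known step offers no direct guide, and both measured values sit low. Compound 3 is therefore expected to remain near them, with a number 2.4 percentage points higher from compound 2 to compound 3 (within the scatter) meaning no step beyond the scatter. The estimate for compound 3 is 8%, between 0% and 25%.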

Compound 3, a percentage reported as inhibition, at one concentration (the size of the read-out at that concentration, not a potency): 0%
Compound 3: middle estimate off by 8 percentage points, on the high side; the measured number falls inside the stated range.
By their numbers in this assay, from the lowest: compounds 3, 2 and 1 (each within the scatter of the next).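

Putting (4-methoxyphenyl)carbamoyl on the oxygen on an aromatic ring in place of 3-(((thiophen-2-yl)carbonyl)amino)propyl gives a number 5.6 percentage points lower from compound 2 to compound 3 (within the scatter) in this assay, and in place of 3-methylbut-2-en-1-yl it gives a number 7.5 percentage points lower from compound 1 to compound 3 (within the scatter). For the compounds shown here, all three groups on this oxygen therefore stay within the scatter of one another, so this change produces no step that can be told apart from it. No further measurement here bears on these numbers. On these data alone, whether a simple amine or a carboxylic acid on this oxygen would give a step beyond the scatter remains open.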